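A Fluorine Added to the Fused Ring of Compound 2

A few compounds are considered here, and "the series" means these few. Any claim that something is new, unique, unknown or untested is made for them only; others in the source may bear on it.

Measured so far in a functional assay on PC-3 cells (Homo sapiens) for inhibition; a lower number here means a stronger inhibitor, a higher number a weaker inhibitor:
compound 1, `CCn1c(=O)/c(=C2\Sc3ccccc3N2C)s/c1=C\c1ccncc1Nc1ccccc1F`, gives 360 nM
compound 2, `CCn1c(=O)/c(=C2\Sc3ccccc3N2C)s/c1=C\c1ccncc1Nc1ccccc1C`, gives 1200 nM
compound 3, `CCn1c(=O)/c(=C2\Sc3ccccc3N2C)s/c1=C\c1ccncc1Nc1cc(F)ccc1F`, gives 1200 nM

Compound 2 differs from compound 1 by methyl in place of fluoro on an aromatic carbon, and that step reads a 3.3-fold higher number from compound 1 to compound 2 (0.52 log units; beyond the scatter). Compound 3 differs from compound 1 by fluoro in place of hydrogen on an aromatic carbon, giving a 3.3-fold higher number from compound 1 to compound 3 (0.52 log units; beyond the scatter). Compound 2 and compound 3 sit together at the high end, with no change at the digits printed from compound 2 to compound 3 (within the scatter) between them.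

Compound 4, `CCn1c(=O)/c(=C2\Sc3cc(F)ccc3N2C)s/c1=C\c1ccncc1Nc1ccccc1C`, awaits measurement. It differs from compound 2 by fluoro in place of hydrogen on an aromatic carbon. This is the same kind of change as that from compound 1 to compound 3, but not the same: there the fluoro entered meta to a large group and para to a fluoro group on a plain six-membered ring, whereas here it enters a ring that is part of a fused system, meta and para to a fused ring. The earlier step of a 3.3-fold higher number from compound 1 to compound 3 (0.52 log units; beyond the scatter) makes a modest rise in the number the expectation here, a 1.5-fold higher number from compound 2 to compound 4 (0.18 log units; within the scatter), though the different place widens the uncertainty. Compound 4 is therefore estimated at 1800 nM, expected to fall between 600 nM and 5500 nM.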

Compound 4, half-maximal inhibitory concentration: 2300 nM
Beside the measured number, compound 4's estimate is 1.3-fold (0.11 log units) below it; the measured number falls inside the stated range.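

In this assay, adding a fluoro group to the fused ring gives a 1.9-fold higher number from compound 2 to compound 4 (0.28 log units; within the scatter), a step that cannot be told apart from the scatter of repeated measurements. Set beside the earlier fluoro step, it does not differ from that step by more than the scatter allows: the same change on two cores in this assay, a 3.3-fold higher number (0.52 log units; beyond the scatter) from compound 1 to compound 3 and a 1.9-fold higher number (0.28 log units; within the scatter) from compound 2 to compound 4, 1.7-fold (0.24 log units) apart, within the scatter of two such steps. Going by these compounds alone, this shows that the two results are compatible, but not that the change carries over reliably: there are only two examples, the fluoro enters a different ring in each, and one step lies within the scatter.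

The compounds shown leave open whether a chloro group, a methoxy group or an amine at the same place on the fused ring would move the number beyond the scatter. They also leave open how this fused-ring fluoro would behave on compound 1.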